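Defluorination of the Pyridine Ring in a Thiosemicarbazide Series

This account rests on a few compounds, and the source may have more. Where it says the series, first, only, none or still open, it means among the compounds named here.

Compound 1 `N/C(=N\NC(=S)N1CCCC1)c1ccc(F)cn1` gives the lower of two numbers in a functional assay on MCF7 cells (Homo sapiens) for cytotoxicity, read by MTT assay, with a stated time of 72 h (a higher number here means a weaker inhibitor, a lower number a stronger inhibitor), at 900 nM. Compound 2 `N/C(=N\NC(=S)N1CCOCC1)c1ccc(F)cn1` reaches only 22100 nM in this assay, and a 25-fold higher number from compound 1 to compound 2 (1.39 log units; beyond the scatter). Compound 3 `N/C(=N\NC(=S)N1CCCC1)c1ccccn1` differs from compound 1 by hydrogen in place of fluoro on an aromatic carbon. Among the compounds with values here, the one measured step alters the thiocarbonyl amine, not the aromatic ring, so it does not bear on this change. Within the data shown here, with no relevant precedent, the step of a 1.7-fold higher number from compound 1 to compound 3 (0.22 log units; within the scatter) is expected to be modest, and compound 3 is estimated at 1500 nM, within a range of 450 nM to 5000 nM.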

Compound 3, half-maximal inhibitory concentration: 3600 nM
Compound 3: the middle estimate sits 2.4-fold (0.38 log units) below what was measured, and the stated range covers the measured number.
By their numbers in this assay, from the lowest: compound 1; then compound 3; then compound 2.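

With hydrogen in place of fluoro on the aromatic carbon, the shared core shows a 4.0-fold higher number from compound 1 to compound 3 (0.60 log units; beyond the scatter) in this assay. The number therefore responds to the aromatic ring as well as to the thiocarbonyl amine, the only site varied in the earlier step. Nothing shown gives a reason for this step. The compounds shown leave open whether chloro, methoxy or an amine on this aromatic carbon would match fluoro. They also leave open whether the fluoro step would hold with morpholin-4-yl in place of pyrrolidin-1-yl.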